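Urea aryl swap on a shared pyrazole-bearing scaffold

The compounds below may be only part of what the source reports. "The series", "measured", "known", "first", "only" and "open" are said of these compounds alone.

Of the compounds shown here, three built on one shared core have been measured in a functional assay on LOX IMVI cells (Homo sapiens) for inhibition, read by sulforhodamine B assay, with a stated time of 48 h, tested at 10 uM; a higher number here means a weaker effect of the compound at the concentration tested, a lower number a stronger effect. Compound 1 `COc1cc(Cl)cc(-c2nn(-c3cccc(NC(=O)c4ccc(Cl)c(Cl)c4)c3)cc2-c2ccncc2)c1` carries a 3,4-dichlorophenyl on a carbonyl carbon and in this assay compound 1 gives 72.8%. Compound 3 `COc1cc(Cl)cc(-c2nn(-c3cccc(NC(=O)Nc4ccc(Cl)c(Cl)c4)c3)cc2-c2ccncc2)c1` carries a (3,4-dichlorophenyl)amino on that carbonyl carbon instead, and in this assay compound 3 gives 9.24%. The step of a number 63.6 percentage points lower from compound 1 to compound 3 (beyond the scatter) is the only one in this set that is computed, and it lies well beyond the scatter. Compound 2 `COc1cc(Cl)cc(-c2nn(-c3cccc(NC(=O)Nc4cc(C(F)(F)F)cc(C(F)(F)F)c4)c3)cc2-c2ccncc2)c1` is the remaining urea, and in this assay compound 2 gives -24%. Compound 3 thus stands second highest of the three numbers: nearer to compound 2 and far from compound 1.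

Compound 4 `COc1cc(Cl)cc(-c2nn(-c3cccc(NC(=O)Nc4cccc(C(F)(F)F)c4)c3)cc2-c2ccncc2)c1` differs from compound 3 by 3-(trifluoromethyl)phenyl in place of 3,4-dichlorophenyl on an amide-type nitrogen. For the measured compounds named here, no measured step touches this exact change; the step from compound 1 to compound 3 concerns the amide-to-urea change, not the aryl on the urea nitrogen. The values of compound 2 and compound 3, both ureas with halogenated aryls, lie within a modest span of each other, so the author expects compound 4 to fall in the same region, with a number 4.2 percentage points lower from compound 3 to compound 4 (within the scatter) as a step no larger than the scatter. The estimate for compound 4 in this assay is 5%, ranging from -25% to 35%.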

Compound 4, a percentage reported as activity, at one concentration (the size of the read-out at that concentration, not a potency): 4.64%
The estimate for compound 4 lay 0.4 percentage points above the measured number, within the range that was stated.
By their numbers in this assay, from the lowest: compound 2; then compounds 4 and 3 (each within the scatter of the next); then compound 1.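

In this assay, for the compounds shown here, a number 4.6 percentage points lower from compound 3 to compound 4 (within the scatter) shows that on the urea nitrogen a single 3-(trifluoromethyl)phenyl and a 3,4-dichlorophenyl are not told apart, a comparison the earlier compounds could not offer. The aryl on the urea is still not indifferent to change: with hydrogen in place of one trifluoromethyl on an aromatic carbon, a number 28.6 percentage points higher from compound 2 to compound 4 (beyond the scatter), so the second trifluoromethyl of compound 2 makes a difference that exceeds the scatter, while a number 68.2 percentage points lower from compound 1 to compound 4 (beyond the scatter) shows that the large gap between the amide compound 1 and the ureas also holds for this second urea aryl. Nothing available here explains either the shift on losing the trifluoromethyl or the gap to the amide.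

These compounds leave open whether the aryl on the urea nitrogen tolerates anything other than halogen or trifluoromethyl substituents, such as a nitrile, a methoxy, an amine or a carboxylic acid. They also leave open whether a cyclohexyl or a short alkyl chain could replace that aryl altogether while keeping the numbers of the ureas.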